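A few compounds are considered here, and "the series" means these few. Any claim that something is new, unique, unknown or untested is made for them only; others in the source may bear on it.

Measured so far in a functional assay on the whole organism (strain Wistar) for inhibition, with Rattus norvegicus as the target, read by paw edema, with a stated time of 2 h, at a dose of 10 mg/kg by the intraperitoneal route; on this read-out lower numbers stand for less inhibition and higher numbers for more inhibition at the one dose given (going by the name of the read-out):
compound 1 `O=C(N/N=C/c1ccccc1)c1cccnc1Nc1cccc(C(F)(F)F)c1`: 36.8%
compound 2 `O=C(N/N=C/c1cccc(Cl)c1)c1cccnc1Nc1cccc(C(F)(F)F)c1`: 63.5%
compound 3 `O=C(N/N=C/c1cccc(O)c1)c1cccnc1Nc1cccc(C(F)(F)F)c1`: 65.4%

Compound 3 gives the highest of the three numbers; compound 2 lies within the scatter of it, compound 1 beyond it. Two steps leave compound 1: a number 26.7 percentage points higher from compound 1 to compound 2 (beyond the scatter) and a number 28.6 percentage points higher from compound 1 to compound 3 (beyond the scatter). Each substitution on an aromatic carbon raised inhibition by a modest margin. Between the two substituted compounds a number 1.9 percentage points higher from compound 2 to compound 3 (within the scatter), so chloro and hydroxy are not told apart here.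

Compound 4 `COc1ccc(/C=N/NC(=O)c2cccnc2Nc2cccc(C(F)(F)F)c2)cc1` carries 4-methoxyphenyl in place of 3-hydroxyphenyl on a carbon with a double bond to nitrogen. Going by the values given here, no measured pair holds a methoxy group, so no step bears directly on this change; the nearest guide is that both substituted rings, compound 2 and compound 3, stand well above the unsubstituted compound 1. A substituted ring is therefore expected to hold near the level of compound 2 and compound 3, with an allowance downward for the unknown group: the step of a number 10.4 percentage points lower from compound 3 to compound 4 (beyond the scatter) is expected, within the scatter. Compound 4 is estimated at 55%, between 35% and 72%.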

Compound 4, a percentage reported as inhibition, in the whole organism at one dose (the size of the read-out at that dose, not a potency): 42.4%
Compound 4: middle estimate off by 12.6 percentage points, on the high side, and the stated range covers the measured number.
By their numbers in this assay, from the lowest: compounds 1 and 4 (each within the scatter of the next); then compounds 2 and 3 (each within the scatter of the next).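

In this assay, a substituent on this ring does not by itself lift the number: a number 23 percentage points lower from compound 3 to compound 4 (beyond the scatter) and a number 21.1 percentage points lower from compound 2 to compound 4 (beyond the scatter), while a number 5.6 percentage points higher from compound 1 to compound 4 (within the scatter), which leaves the methoxy compound not told apart from the compound with no substituent. The rise shared by the chloro and hydroxy compounds therefore does not extend to 4-methoxyphenyl on the carbon with a double bond to nitrogen, and compound 4 goes against any pattern of substituted rings standing above the bare phenyl. No supporting evidence is available to explain this difference.

The change from 3-hydroxyphenyl to 4-methoxyphenyl alters both the group and its place on the ring, and these compounds do not separate the two. Going by these compounds, how an amino group or a carboxylic acid on this ring would read also remains open.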